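The source may report more compounds than this note shows. Statements on the series, on what has been measured and on what is new or still open speak of the compounds shown alone.

Of the compounds shown here, two sharing one core have been tested in an ADME assay on MT4 cells (Homo sapiens) for cytotoxicity, read by MTT assay, with a stated time of 5 days; on this read-out lower numbers stand for higher toxicity in this test and higher numbers for lower toxicity in this test. Compound 1 `Cc1cc(/C=C/C#N)cc(C)c1Oc1nc(Nc2ccc(N3CCCC(NS(C)(=O)=O)C3)cc2)nc2sccc12` gives 112000 nM. Compound 2 `Cc1cc(/C=C/C#N)cc(C)c1Oc1nc(Nc2ccc(N3CCN(S(C)(=O)=O)CC3)cc2)nc2sccc12` gives > 222000 nM, which is a limit of this assay rather than a number. The step of an at least 1.9-fold higher number from compound 1 to compound 2 (0.29 log units; that floor lies within the scatter) is therefore only a floor, and that floor lies within the scatter, so the two compounds cannot be ordered on these data. Compound 2 stands at the limit of > 222000 nM in this assay, at which 1 of the 2 values shown sits, where the read-out stops.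

Compound 3 `Cc1cc(/C=C/C#N)cc(C)c1Oc1nc(Nc2ccc(CN3CCN(S(N)(=O)=O)CC3)cc2)nc2sccc12` differs from compound 2 in a single place: (4-sulfamoylpiperazin-1-yl)methyl in place of 4-(methylsulfonyl)piperazin-1-yl on an aromatic carbon. For the measured compounds named here, the only measured step that bears on a change at this cyclic amine is the one from compound 1 to compound 2, and it showed no shift that could be told from the scatter. The expected step is therefore an at least 1.2-fold lower number from compound 2 to compound 3 (0.09 log units; that floor lies within the scatter), that is, none beyond the scatter, with compound 3 staying in the weakly toxic region already seen. Compound 3 is estimated at 180000 nM, with a range from 80000 nM to 400000 nM, and the measurement may again return only a limit.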

Compound 3, half-maximal cytotoxic concentration: > 217000 nM
Compound 3: no number, only a limit (the forecaster's own chance of this, stated with the estimate: 55%); middle value at least 1.2-fold (0.08 log units) away from the limit.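

In this assay compound 3 also returns no number, and its value is a limit of the assay: the limit of > 217000 nM in this assay, at which 1 of the 3 values shown sits. At this aromatic carbon, para to a large group, (4-sulfamoylpiperazin-1-yl)methyl therefore ends at a limit of the read-out, just as 4-(methylsulfonyl)piperazin-1-yl did, so a second group at this place has failed to bring a number into the measurable range. Set against the one measured number in the series, the data show an at least 1.9-fold higher number from compound 1 to compound 3 (0.28 log units; that floor lies within the scatter), so this pair stays unordered as well, and the step between the two limits cannot be read.

Where compound 2 and compound 3 stand relative to each other in this assay stays open, as does the question of whether the added methyl link or the swap of methylsulfonyl for sulfamoyl has any effect of its own. Going by these compounds, it is also open whether a piperazine carrying a free amine or a carboxylic acid in place of the sulfamoyl group, on the same link, would return a number rather than a limit.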